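The source may hold more compounds than are shown below. What is called first, only, known or untested is meant among the compounds shown, and "the series" means these compounds.

In a functional assay on NCI-H460 cells (Homo sapiens) for antiproliferative activity (a higher number here means a weaker inhibitor, a lower number a stronger inhibitor), compound 1 `Cc1ccc(N=C2NC(=O)/C(=C\c3ccc(N(C)C)cc3)S2)cc1` gives 940 nM and compound 2 `CN(C)c1ccc(/C=C2/SC(=Nc3ccccc3Cl)NC2=O)cc1` gives 730 nM, so these two stand level within the usual scatter. Compound 3 `CN(C)c1ccc(/C=C2/SC(=Nc3ccccc3)NC2=O)cc1` has not been measured. It differs from compound 2 by hydrogen in place of chloro on an aromatic carbon, which is hydrogen in place of chloro on an aromatic carbon. Going by the values given here, the only measured step that bears on this is a 1.3-fold lower number from compound 1 to compound 2 (0.11 log units; within the scatter), a change in the group on a double-bonded nitrogen, and it stays within the scatter. Nothing beyond the scatter is therefore expected in this assay, and the expected step is a 1.2-fold higher number from compound 2 to compound 3 (0.07 log units; within the scatter). For compound 3 the estimated value is 850 nM, with a range from 380 nM to 1900 nM.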

Compound 3, half-maximal inhibitory concentration: 500 nM
Estimate against measurement, compound 3: 1.7-fold (0.23 log units) above; low and high end bracket the measured number.
By their numbers in this assay, from the lowest: compounds 3, 2 and 1 (each within the scatter of the next).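

In this assay, taking the chloro off gives a 1.5-fold lower number from compound 2 to compound 3 (0.16 log units; within the scatter), and taking the methyl off gives a 1.9-fold lower number from compound 1 to compound 3 (0.27 log units; within the scatter). The plain phenyl therefore stands level with both the 2-chlorophenyl and the 4-methylphenyl, so neither substituent is required for activity at this level. No measured evidence bears on why these changes leave the number within the scatter.

The compounds shown carry only chloro, methyl or hydrogen on this aromatic ring. On these data alone, what an amine or a carboxylic acid there would do remains open, as does any change to the dimethylamino group.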